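The source may hold more compounds than are shown below. What is called first, only, known or untested is meant among the compounds shown, and "the series" means these compounds.

Series notes on antagonism at the rat receptor. Compound 1 `Cc1nc(C#Cc2cc(C#N)cc([N+](=O)[O-])c2)cs1` gives in a functional assay on HEK293 cells for antagonist activity at metabotropic glutamate receptor 5 (Rattus norvegicus), read by calcium flux (a lower number here means a stronger inhibitor, a higher number a weaker inhibitor), a value of 2.63 nM. Compound 2 `Cc1nc(C#Cc2cc(I)cc(C#N)c2)cs1` gives in this assay 1.05 nM; the two differ in one change, (iodo in place of nitro on an aromatic carbon), and the step is a 2.5-fold lower number from compound 1 to compound 2 (0.40 log units; beyond the scatter). Compound 3 `N#Cc1cc(C#Cc2ccccn2)cc([N+](=O)[O-])c1` carries a different core, the difference from compound 1 being (pyridin-2-yl in place of 2-methyl-1,3-thiazol-4-yl on a triple-bonded carbon); in this assay compound 3 gives 1.32 nM, a step of a 2.0-fold lower number from compound 1 to compound 3 (0.30 log units; within the scatter). Compound 3 and compound 2 lie within the scatter of each other.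

Compound 4 `N#Cc1cc(I)cc(C#Cc2ccccn2)c1` has not been measured in this assay. It stands to compound 3 as compound 2 stands to compound 1: the change is iodo in place of nitro on an aromatic carbon, made at a place described word for word as in the measured pair, so it is the same change, here applied to the core of compound 3. Among the measured compounds shown here, the only guide to its size is the single measured instance, a 2.5-fold lower number from compound 1 to compound 2 (0.40 log units; beyond the scatter); one pair cannot show whether the step carries across cores. For compound 4 the expected step is a 2.4-fold lower number from compound 3 to compound 4 (0.38 log units; beyond the scatter), resting on the measured 2.5-fold lower number from compound 1 to compound 2 (0.40 log units; beyond the scatter). Compound 4 is expected to give 0.55 nM in this assay, with a range from 0.25 nM to 1.3 nM.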

Compound 4, half-maximal inhibitory concentration: 0.66 nM
Beside the measured number, compound 4's estimate is 1.2-fold (0.08 log units) below it; measured number inside the range.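

In this assay, iodo in place of nitro on the core of compound 3 gives a 2.0-fold lower number from compound 3 to compound 4 (0.30 log units; within the scatter), so this step taken alone does not separate the pair. Set beside the earlier instance, the two steps do not differ: the same change on two cores in this assay, a 2.5-fold lower number (0.40 log units; beyond the scatter) from compound 1 to compound 2 and a 2.0-fold lower number (0.30 log units; within the scatter) from compound 3 to compound 4, 1.3-fold (0.10 log units) apart, within the scatter of two such steps. Within this small set, the change therefore carries between the core of compound 1 and the core of compound 3 with no detectable difference in size, but this rests on two pairs, one of them within the scatter, and does not show that the step is the same on any further core or explain why it carries.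

The compounds shown leave open how other groups on that aromatic carbon, such as an amine, a carboxylic acid or a bromo group, would compare with nitro and iodo. They also leave open whether the step would hold if a phenyl group stood in place of pyridin-2-yl or 2-methyl-1,3-thiazol-4-yl on the triple-bonded carbon.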